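A few compounds are considered here, and "the series" means these few. Any claim that something is new, unique, unknown or untested is made for them only; others in the source may bear on it.

Three compounds with the same core differ only in the chain on the amine nitrogen in a ring, and all were tested in a functional assay on cells (T-cell line, Homo sapiens) for inhibition (a lower number here means a stronger inhibitor, a higher number a weaker inhibitor), as inhibitors. Compound 1 `CCN1CCC(COC(c2ccccc2)c2ccccc2)CC1` has the shortest chain, and its reading of > 20000 nM is a limit of the assay and not a number. Compound 2 `CCCCN1CCC(COC(c2ccccc2)c2ccccc2)CC1` gives 14000 nM in this assay with a longer chain. Compound 3 `CCCCCCCCN1CCC(COC(c2ccccc2)c2ccccc2)CC1` has the longest chain and stands lowest of the three at 700 nM in the same test. Lengthening the chain gave a 20-fold lower number from compound 2 to compound 3 (1.30 log units; beyond the scatter) and an at least 28-fold lower number from compound 1 to compound 3 (1.45 log units; beyond the scatter), both large, while an at least 1.4-fold lower number from compound 1 to compound 2 (0.15 log units; that floor lies within the scatter) has a floor within the scatter.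

Compound 4 `c1ccc(C(OCC2CCN(CC3CCc4ccccc4C3)CC2)c2ccccc2)cc1` brings a different kind of change: 1,2,3,4-tetrahydronaphthalen-2-yl replaces heptyl on a saturated chain carbon bound to an amine nitrogen in a ring, as counted in 1,2,3,4-tetrahydronaphthalen-2-yl in place of heptyl on a saturated chain carbon bound to an amine nitrogen in a ring here. The measured steps only lengthen a plain chain and none introduces a ring, so they bear on this change only loosely. The entering group is larger, yet it is not a longer chain, so no step beyond the scatter is expected in this assay for now. The expected change is a 1.2-fold lower number from compound 3 to compound 4 (0.07 log units; within the scatter) and this estimate is uncertain. For compound 4 the estimated value is 600 nM, with an expected range from 150 nM to 3000 nM as its limits.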

Compound 4, half-maximal inhibitory concentration: 5600 nM
Beside the measured number, compound 4's estimate is 9.3-fold (0.97 log units) below it, outside the stated range (above it).
By their numbers in this assay, from the lowest: compound 3; then compound 4; then compound 2. At a limit, above all of these: compound 1.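

Putting a ring-bearing group at this place does not act like simply lengthening the chain: in this assay, 1,2,3,4-tetrahydronaphthalen-2-yl in place of heptyl on a saturated chain carbon bound to an amine nitrogen in a ring gives an 8.0-fold higher number from compound 3 to compound 4 (0.90 log units; beyond the scatter), even though the entering group has more heavy atoms than the one leaving. The same group still improves on the shorter chain, with a 2.5-fold lower number from compound 2 to compound 4 (0.40 log units; beyond the scatter), so among these four compounds, the number of carbons in the group does not alone set the reading, and compound 4 goes against the trend seen in compounds 1 to 3. Compound 1 reads as a limit of the assay and not a number, so the step to the ring-bearing group, an at least 3.5-fold lower number from compound 1 to compound 4 (0.55 log units; beyond the scatter), gives only a floor: the limit of > 20000 nM in this assay, at which 1 of the 4 values shown sits.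

On these data alone, it remains open whether the aromatic ring or the non-aromatic ring of the entering group accounts for the gap to compound 3, and how a phenyl or cyclohexyl group at this place would read. Also open, as far as these compounds go, is whether a longer chain than that of compound 3 would lower the number further.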